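Lengthening the amide chain from ethyl to propyl

A few compounds are considered here, and "the series" means these few. Any claim that something is new, unique, unknown or untested is made for them only; others in the source may bear on it.

Measured in a functional assay on NCI-H1975 cells (Homo sapiens) for inhibition, with a stated time of 72 h; on this read-out lower numbers stand for stronger inhibition of growth and higher numbers for weaker inhibition of growth:
- compound 1 `CCCN(Cc1ccc(C(=O)NO)cc1)C(=O)c1cc(Cl)c(O)cc1O`: 73600 nM
- compound 2 `CC(C)c1cc(C(=O)N(C)Cc2ccc(C(=O)NO)cc2)c(O)cc1O`: 1700 nM
- compound 3 `CCN(Cc1ccc(C(=O)NO)cc1)C(=O)c1cc(C(C)C)c(O)cc1O`: 7000 nM

Compound 3 holds the second highest of the three numbers at 7000 nM, above compound 2 and below compound 1. The next analogue is compound 4 `CCCN(Cc1ccc(C(=O)NO)cc1)C(=O)c1cc(C(C)C)c(O)cc1O`, and the change is methyl in place of hydrogen on a saturated chain carbon, two bonds along the chain from an amide-type nitrogen, which also reads as ethyl to propyl. The closest measured precedent is a 4.1-fold higher number from compound 2 to compound 3 (0.61 log units; beyond the scatter), a modest step beyond the scatter, made by methyl in place of hydrogen on a saturated chain carbon bound to an amide-type nitrogen. Among the compounds with values here, compound 1 also carries the propyl chain, but the rest of its structure differs, and its 73600 nM gives no clean step for this change. Within the data shown here, a single step sets no trend, so a modest rise in this assay is expected, no larger than the precedent. The estimated change is a 1.7-fold higher number from compound 3 to compound 4 (0.23 log units; within the scatter). For compound 4 the expected value is 12000 nM, with an estimated range of 4500 nM to 32000 nM.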

Compound 4, concentration for 50% growth inhibition: 23700 nM
For compound 4 the middle estimate is 2.0-fold (0.30 log units) below the measured one; the range from low to high includes it.
By their numbers in this assay, from the lowest: compound 2; then compound 3; then compound 4; then compound 1.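

In this assay the second chain extension runs in the same direction as the first: a 3.4-fold higher number from compound 3 to compound 4 (0.53 log units; beyond the scatter) follows a 4.1-fold higher number from compound 2 to compound 3 (0.61 log units; beyond the scatter), so the numbers rise through methyl, ethyl and propyl on the amide-type nitrogen, with a 14-fold higher number from compound 2 to compound 4 (1.14 log units; beyond the scatter) across the whole run. Within the data shown here, the propyl chain also gives the first single-place reading of the aromatic group, with isopropyl in place of chloro on an aromatic carbon: a 3.1-fold lower number from compound 1 to compound 4 (0.49 log units; beyond the scatter). Nothing available bears on the reason for these steps.

Going by these compounds, whether a butyl chain, or a chain ending in an amine, would extend the rise remains open. So does whether isopropyl and chloro would differ in the same direction with a methyl or ethyl chain on the amide-type nitrogen.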